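This account rests on a few compounds, and the source may have more. Where it says the series, first, only, none or still open, it means among the compounds named here.

Compound 3 `Brc1ccc2ccn(CCN3CCCN(CC4CC4)CC3)c2c1` gives 9 nM in an assay on HEK293 cells for binding affinity to 5-hydroxytryptamine receptor 7 (Homo sapiens), read by radioligand binding; on this read-out lower numbers stand for stronger inhibition and higher numbers for weaker inhibition; compound 1 `CC(C)N1CCCN(CCn2ccc3ccc(Br)cc32)CC1` gives 14 nM and compound 2 `CC(C)CN1CCCN(CCn2ccc3ccc(Br)cc32)CC1` gives 37 nM, so compound 3 holds the lowest of the three numbers, with a 1.6-fold lower number from compound 1 to compound 3 (0.19 log units; within the scatter) and a 4.1-fold lower number from compound 2 to compound 3 (0.61 log units; beyond the scatter). Compound 4 `Brc1ccc2ccn(CCN3CCCN(C4CCCCC4)CC3)c2c1` differs from compound 3 by cyclohexyl in place of cyclopropylmethyl on an amine nitrogen in a ring. Among the measured compounds shown here, the steps that bear on this change are a 2.6-fold higher number from compound 1 to compound 2 (0.42 log units; beyond the scatter), where isobutyl in place of isopropyl gave the higher number, a 4.1-fold lower number from compound 2 to compound 3 (0.61 log units; beyond the scatter), and a 1.6-fold lower number from compound 1 to compound 3 (0.19 log units; within the scatter). For the measured compounds named here, since the one enlargement of the group on this nitrogen raised the number modestly, a modest upward step is expected for compound 4, a 2.8-fold higher number from compound 3 to compound 4 (0.44 log units; beyond the scatter). Compound 4 is therefore estimated at 25 nM, with a range from 8 nM to 80 nM.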

Compound 4, inhibition constant: 17 nM
The estimate for compound 4 lay 1.5-fold (0.17 log units) above the measured number, and the stated range covers the measured number.
By their numbers in this assay, from the lowest: compounds 3, 1 and 4 (each within the scatter of the next); then compound 2.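

In this assay the cyclohexyl group on the amine nitrogen in a ring keeps the number close to the smaller groups, with a 1.9-fold higher number from compound 3 to compound 4 (0.28 log units; within the scatter) and a 1.2-fold higher number from compound 1 to compound 4 (0.08 log units; within the scatter) both within the scatter, while a 2.2-fold lower number from compound 2 to compound 4 (0.34 log units; beyond the scatter) lies beyond it. The rise seen with isobutyl therefore does not extend to every enlargement of this group, and among these four compounds only compound 2 stands apart. Nothing measured here explains why isobutyl differs from cyclohexyl. From the compounds shown here alone, whether a benzyl group, a longer chain or a hydroxyethyl group on this nitrogen would stay in the same range remains open.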